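Naphthalen-1-ylmethyl in place of benzyl at the thioether

This account rests on a few compounds, and the source may have more. Where it says the series, first, only, none or still open, it means among the compounds named here.

Values in a functional assay on HeLa cells (Homo sapiens) for antiproliferative activity, read by MTT assay, with a stated time of 72 h; a higher number here means a weaker inhibitor, a lower number a stronger inhibitor:
compound 1 `Cc1cc(S(=O)(=O)/N=C(\N)N/N=C/C#Cc2ccccc2)c(SCc2ccccc2)cc1Cl`: 5000 nM
compound 2 `C/C(C#Cc1ccccc1)=N\N/C(N)=N/S(=O)(=O)c1cc(C)c(Cl)cc1SCc1ccccc1Cl`: 25000 nM
compound 3 `C/C(C#Cc1ccccc1)=N\N/C(N)=N/S(=O)(=O)c1cc(C)c(Cl)cc1SCc1ccc(Cl)cc1`: 8000 nM

Compound 1 has the lowest number of the three. Its gap to compound 2 lies beyond the scatter, while its gap to compound 3 lies within it, so compound 1 and compound 3 cannot be told apart on these data.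

Compound 4 `Cc1cc(S(=O)(=O)/N=C(\N)N/N=C/C#Cc2ccccc2)c(SCc2cccc3ccccc23)cc1Cl` is not yet measured in this assay. It differs from compound 1 by naphthalen-1-yl in place of phenyl on a saturated chain carbon bound to a sulfur.

Among the measured compounds shown here, the only measured step touching this place is a 3.1-fold lower number from compound 2 to compound 3 (0.49 log units; beyond the scatter), which shows that altering the aromatic group on the sulfur-bound carbon can shift the number beyond the scatter in either direction without the rest of the molecule changing. For the measured compounds named here, no measured pair shows a ring of two fused six-membered aromatic rings entering at that place, so the direction of the step for compound 4 cannot be read from the data.

Given that a change at this position moved compound 2 to compound 3 by a modest amount, a step of similar size is the most that is expected, and with no basis for a direction the estimate for compound 4 sits near compound 1: a 1.1-fold lower number from compound 1 to compound 4 (0.05 log units; within the scatter), giving an expected value of 4500 nM with a range from 1500 nM to 14000 nM.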

Compound 4, half-maximal inhibitory concentration: 8000 nM
The estimate for compound 4 lay 1.8-fold (0.25 log units) below the measured number; the range from low to high includes it.
By their numbers in this assay, from the lowest: compounds 1, 3 and 4 (each within the scatter of the next); then compound 2.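

In this assay, the step from phenyl to naphthalen-1-yl on a saturated chain carbon bound to a sulfur is a 1.6-fold higher number from compound 1 to compound 4 (0.20 log units; within the scatter), so this place accepts the larger naphthalen-1-yl group with no change that can be told from the scatter. The earlier step, a 3.1-fold lower number from compound 2 to compound 3 (0.49 log units; beyond the scatter), showed only that this place can respond to moving a chlorine around the phenyl ring; the present step adds that a much bigger aromatic group need not move the number at all, so size of the group alone does not track with the response across these two pairs. Nothing available on the properties of these groups or on how the compounds act bears on this result.

Open, as far as these compounds go, is whether the same replacement gives the same outcome on the core of compound 2, where the two chlorophenyl groups were compared, since the two steps sit on a different core from each other. Also open, from the compounds shown here alone, is how this place responds to naphthalen-2-yl, to a longer chain such as 2-phenylethyl, or to a phenyl ring carrying an amine or a carboxylic acid.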